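The compounds below may be only part of what the source reports. "The series", "measured", "known", "first", "only" and "open" are said of these compounds alone.

Series notes. In a functional assay on A549 cells (Homo sapiens) for cytotoxicity, read by MTT assay, with a stated time of 48 h (on this read-out lower numbers stand for stronger inhibition and higher numbers for weaker inhibition), compound 1 `Cc1ccc(C(=O)CSc2nnc(C)n2N2C(=O)c3ccccc3C2=O)cc1` reaches only the limit of the assay, > 200000 nM. Compound 2 `CCOC(=O)CSc1nnc(CC)n1N1C(=O)c2ccccc2C1=O` likewise stops at a limit, > 200000 nM. Compound 3 `C=CCSc1nnc(-c2cc(OC)c(OC)c(OC)c2)n1N1C(=O)c2ccccc2C1=O` also gives a limit rather than a number, > 200000 nM. Compound 3 thus stands among the limit values only, and across the three compounds shown nothing separates it from the others, because of the limit of > 200000 nM in this assay, at which 3 of the 3 values shown sit.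

Compound 4 `COc1cc(-c2nnc(SCC(=O)c3ccc(C)cc3)n2N2C(=O)c3ccccc3C2=O)cc(OC)c1OC` differs from compound 3 by (4-methylphenyl)carbonyl in place of vinyl on a saturated chain carbon bound to a sulfur. Within the data shown here, no measured step of this kind exists, so the size of the change is taken as none beyond the scatter, and the estimated step from compound 3 to compound 4 is a number no higher from compound 3 to compound 4 (the limit leaves the size open). Compound 4 is accordingly expected to give about 200000 nM in this assay, within 80000 nM to 500000 nM, most probably again as a limit.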

Compound 4, half-maximal inhibitory concentration: 6760 nM
For compound 4 the middle estimate is 30-fold (1.47 log units) above the measured one; the whole stated range lies above it.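

In this assay, (4-methylphenyl)carbonyl in place of vinyl on a saturated chain carbon bound to a sulfur gives an at least 29-fold lower number from compound 3 to compound 4 (1.47 log units; beyond the scatter), and 3,4,5-trimethoxyphenyl in place of methyl on an aromatic carbon gives an at least 29-fold lower number from compound 1 to compound 4 (1.47 log units; beyond the scatter). Compound 1 carries the first group and compound 3 the second, and only compound 4, with both, leaves the limit, so each change counts here only with the other present. Both steps remain lower bounds because compounds 1 and 3 carry limits: the limit of > 200000 nM in this assay, at which 3 of the 4 values shown sit.

Open, from the compounds shown here alone, is whether an amine or a carboxylic acid in place of (4-methylphenyl)carbonyl keeps the value of compound 4. Also open, going by these compounds, is how far 3,4,5-trimethoxyphenyl can be replaced by a plain phenyl.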